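Swapping the Aryl Ether for a Benzyl Group

The compounds below may be only part of what the source reports. "The series", "measured", "known", "first", "only" and "open" are said of these compounds alone.

Compound 1 `COc1ccc(Oc2ccc3c(NCCCNCc4cc(F)ccc4OC)ccnc3c2)cc1`: in an ADME assay for permeability, using PAMPA, with a stated time of 30 min, at pH 7.4 (on this read-out lower numbers stand for lower permeability and higher numbers for higher permeability), compound 1 gives 317 10^-6 cm/s.
Compound 2 `c1ccc(Oc2ccc3c(NCCCNCc4ccco4)ccnc3c2)cc1`: in this assay compound 2 gives 317 10^-6 cm/s.
Compound 3 `COc1ccc(Oc2ccc3c(NCCCNCc4ccco4)ccnc3c2)cc1`: in this assay compound 3 gives 317 10^-6 cm/s.

Compound 1 stands level with compounds 2 and 3 at the digits reported, its value within the scatter of both. The two measured steps alter other parts of the molecule: no change at the digits printed from compound 1 to compound 3 (within the scatter), and no change at the digits printed from compound 2 to compound 3 (within the scatter). Neither touches the position altered in compound 4 `COc1ccc(F)cc1CNCCCNc1ccnc2cc(Cc3ccccc3)ccc12`, which differs from compound 1 as follows: benzyl in place of 4-methoxyphenoxy on an aromatic carbon. Among the measured compounds shown here, no measured step bears directly on this exchange of one ring-bearing group for another on the shared core. The two steps that do exist show the read-out holding steady while the chain end and a ring substituent are varied, which gives no ground to expect movement here either. The expected step in this assay is no change at the digits printed from compound 1 to compound 4 (within the scatter), none beyond the scatter. Compound 4 is therefore estimated at 317 10^-6 cm/s, with a range from 160 10^-6 cm/s to 500 10^-6 cm/s.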

Compound 4, apparent permeability: 23 10^-6 cm/s
The estimate for compound 4 lay 14-fold (1.14 log units) above the measured number; measured number outside the range, below it.
By their numbers in this assay, from the lowest: compound 4; then compounds 1, 2 and 3 (each within the scatter of the next).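

Among the compounds shown here, putting benzyl in place of 4-methoxyphenoxy on the shared core gives, in this assay, a 14-fold lower number from compound 1 to compound 4 (1.14 log units; beyond the scatter), the only step in this set that goes beyond the scatter. This position therefore matters to the read-out in a way the earlier changes at the chain end and the methoxy site did not reveal, even though both groups carry one six-membered aromatic ring of carbon only. Nothing measured here explains the drop.

The exchange changes two things at once, the oxygen that links the ring to the core and the methoxy on that ring, and the compounds shown cannot separate them. A 4-methoxybenzyl group at this position, or a phenyl ring bound directly to the core, would be needed to tell how much each part contributes.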